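The source may report more compounds than this note shows. Statements on the series, on what has been measured and on what is new or still open speak of the compounds shown alone.

Three compounds share one core and differ only in the group on the amide-type nitrogen. Compound 1 `CCCNC(=O)c1ccc(Oc2nc(-c3c(C)noc3C)cnc2N)cc1` carries propyl, and in a functional assay on HepG2 cells (Homo sapiens) for inhibition, read by MTT assay, with a stated time of 72 h (on this read-out lower numbers stand for stronger inhibition and higher numbers for weaker inhibition), compound 1 gives 6880 nM. Compound 2 `Cc1noc(C)c1-c1cnc(N)c(Oc2ccc(C(=O)NC3CCCCC3)cc2)n1` carries cyclohexyl, and in this assay compound 2 gives 5420 nM. Compound 3 `Cc1noc(C)c1-c1cnc(N)c(Oc2ccc(C(=O)Nc3ccccc3)cc2)n1` carries phenyl, and in this assay compound 3 gives 11800 nM, the highest of the three numbers; the step of a 1.7-fold higher number from compound 1 to compound 3 (0.23 log units; within the scatter) is within the scatter, whereas a 2.2-fold higher number from compound 2 to compound 3 (0.34 log units; beyond the scatter) is a modest step beyond it. Compound 4 `Cc1noc(C)c1-c1cnc(N)c(Oc2ccc(C(=O)Nc3cccc(Cl)c3)cc2)n1` differs from compound 3 by chloro in place of hydrogen on an aromatic carbon, that is, phenyl to 3-chlorophenyl. For the measured compounds named here, none of the measured steps touches a change of this kind: each of them exchanges the whole group on the amide-type nitrogen, and the spread across those exchanges is narrow. There is thus no basis for expecting a step beyond the scatter in this assay in either direction. The estimate for compound 4 is 9500 nM, with a range from 3500 nM to 26000 nM, which means an expected step of a 1.2-fold lower number from compound 3 to compound 4 (0.09 log units; within the scatter).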

Compound 4, half-maximal inhibitory concentration: 7300 nM
For compound 4 the middle estimate is 1.3-fold (0.11 log units) above the measured one; the range from low to high includes it.
By their numbers in this assay, from the lowest: compounds 2, 1, 4 and 3 (each within the scatter of the next, the first and the last beyond it).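

For the compounds shown here, compound 4 is the first compound in this set to alter the group on the amide-type nitrogen by a single substitution, not by exchanging the whole group. In this assay, chloro in place of hydrogen on the phenyl group gives a 1.6-fold lower number from compound 3 to compound 4 (0.21 log units; within the scatter), so this change at this place stays within the scatter. The 3-chlorophenyl group also cannot be told apart from either cyclohexyl, with a 1.3-fold higher number from compound 2 to compound 4 (0.13 log units; within the scatter), or propyl, with a 1.1-fold higher number from compound 1 to compound 4 (0.03 log units; within the scatter), whereas phenyl stood beyond the scatter from cyclohexyl.

The compounds shown leave open whether a chloro elsewhere on the phenyl group, or a methoxy group, an amine or a carboxylic acid at this same place, would give a step beyond the scatter. Nothing shown here offers an explanation for the step from hydrogen to chloro.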